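The source may report more compounds than this note shows. Statements on the series, on what has been measured and on what is new or still open speak of the compounds shown alone.

Compound 1, `CCOC(=O)N1CCC(N2CCC[C@@H](NC(=O)c3cccc(OC)c3)C2)CC1` — > 10000 nM
Compound 2, `CCOC(=O)N1CCC(N2CCC[C@@H](NC(=O)C3CCCCC3)C2)CC1` — > 10000 nM
Compound 3, `CCOC(=O)N1CCC(N2CCC[C@@H](NC(=O)c3cccc(F)c3)C2)CC1` — > 10000 nM

In a functional assay on CHO cells for agonist activity at muscarinic acetylcholine receptor M5 (Rattus norvegicus) (a higher number here means that more compound is needed for the effect, a lower number that less compound is needed), compound 1 gives > 10000 nM, which is a limit of the assay and not a number. Compound 2 likewise gives a limit, > 10000 nM. Compound 3 also gives a limit, > 10000 nM. All three sit at the limit of > 10000 nM in this assay, at which 3 of the 3 values shown sit, so compound 1 stands at the limit with the others, and nothing separates them.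

The unmeasured compound 4, `CCOC(=O)N1CCC(N2CCC[C@@H](NC(=O)c3ccc(F)cc3C)C2)CC1`, differs from compound 1 in one place: 4-fluoro-2-methylphenyl in place of 3-methoxyphenyl on a carbonyl carbon. The measured steps that bear on this are a step that the two limits leave unreadable from compound 1 to compound 2 and a step that the two limits leave unreadable from compound 1 to compound 3; both start from compound 1 and both end at a limit, so their size is not readable. The step that the two limits leave unreadable from compound 2 to compound 3 is equally unreadable.

With no readable step among the measured compounds, a step from compound 1 to compound 4 is expected to be a step that the limit leaves unreadable from compound 1 to compound 4, most likely ending again at the limit. Compound 4 is therefore estimated at 15000 nM, in the range 5000 nM to 50000 nM.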

Compound 4, half-maximal effective concentration: > 10000 nM
Compound 4 ended at the assay's limit (the forecaster's own chance of this, stated with the estimate: 85%); the middle value does not contradict the limit.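

In this assay compound 4 gives > 10000 nM as a limit and not a number. Among the compounds shown here, no step among compound 1, compound 2, compound 3 and compound 4 can be read: the limit of > 10000 nM in this assay, at which 4 of the 4 values shown sit. The compounds shown leave open whether any group on the carbonyl carbon gives a readable value in this assay at all.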